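The compounds below may be only part of what the source reports. "The series", "measured", "known", "first", "only" and "open" are said of these compounds alone.

Of the compounds shown here, three built on one shared core have been measured. In a functional assay on MCF7 cells (Homo sapiens) for antiproliferative activity, read by MTT assay, with a stated time of 72 h (a higher number here means a weaker inhibitor, a lower number a stronger inhibitor), compound 1 `Cc1cc(S(=O)(=O)/N=C(\N)N/N=C/C#Cc2ccccc2)c(SCc2ccccc2C)cc1Cl` gives 13000 nM; compound 2 `Cc1cccc(CSc2cc(Cl)c(C)cc2S(=O)(=O)/N=C(\N)N/N=C/C#Cc2ccccc2)c1` gives 16000 nM; and compound 3 `C/C(C#Cc1ccccc1)=N\N/C(N)=N/S(=O)(=O)c1cc(C)c(Cl)cc1SCc1cccc(C(F)(F)F)c1` gives 20000 nM, the highest of the three numbers, though its gaps to both others lie within the scatter. Among the measured compounds shown here, the only measured step at the saturated chain carbon bound to a sulfur, a 1.2-fold higher number from compound 1 to compound 2 (0.09 log units; within the scatter), is likewise within the scatter. Compound 4 `C/C(C#Cc1ccccc1)=N\N/C(N)=N/S(=O)(=O)c1cc(C)c(Cl)cc1SCc1cccc2ccccc12` changes that same place: naphthalen-1-yl in place of 3-(trifluoromethyl)phenyl on a saturated chain carbon bound to a sulfur. For the measured compounds named here, no measured step swaps an aromatic substituent for a second ring, so the one small step at this place is the sole guide, and a change no larger than the scatter is therefore expected, as no change at the digits printed from compound 3 to compound 4 (within the scatter). Compound 4 is accordingly estimated at 20000 nM, within a range from 8000 nM to 50000 nM.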

Compound 4, half-maximal inhibitory concentration: 210000 nM
Compound 4: middle estimate off by 11-fold (1.02 log units), on the low side; measured number above the stated range.
By their numbers in this assay, from the lowest: compounds 1, 2 and 3 (each within the scatter of the next); then compound 4.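

At the saturated chain carbon bound to a sulfur, the aromatic group is not freely exchangeable, as the small earlier step alone might have suggested: in this assay, naphthalen-1-yl in place of 3-(trifluoromethyl)phenyl gives an 11-fold higher number from compound 3 to compound 4 (1.02 log units; beyond the scatter). The two groups hold the same number of heavy atoms, so this large step comes with a swap of trifluoromethyl for a second six-membered aromatic ring, not with a change in heavy-atom count. Nothing measured here accounts for the step.

From the compounds shown here alone, whether the second ring, its attachment or the missing trifluoromethyl matters most remains open. Naphthalen-2-yl or an unsubstituted phenyl at this place would help separate them.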